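Bromophenyl triazine: an ortho-chloro step

A few compounds are considered here, and "the series" means these few. Any claim that something is new, unique, unknown or untested is made for them only; others in the source may bear on it.

Measured compounds and their values:
compound 1 `Nc1nc(N)nc(-c2cc(F)ccc2Cl)n1` — 78%
compound 2 `Nc1nc(N)nc(-c2cccc(Br)c2)n1` — 96%
compound 3 `CSc1cccc(-c2nc(N)nc(N)n2)c1` — 49%

In a functional assay on the whole organism with Rattus norvegicus as the target, at a dose of 20 mg/kg by the intraperitoneal route (on this read-out higher numbers stand for more inhibition at the one dose given (going by the name of the read-out) and lower numbers for less inhibition), compound 2 stands highest of the three, with compound 1 the nearest below it, beyond the scatter, and compound 3 the furthest below it, also beyond the scatter. Among the measured compounds shown here, the one single-place step among the measured compounds is a number 47 percentage points lower from compound 2 to compound 3 (beyond the scatter), a methylsulfanyl in place of bromo on an aromatic carbon, a large loss.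

The unmeasured compound 4 `Nc1nc(N)nc(-c2cc(Br)ccc2Cl)n1` differs from compound 2 by chloro in place of hydrogen on an aromatic carbon.

For the measured compounds named here, no measured step concerns this exact change. Compound 1 carries the same chloro on its ring and, with a fluoro instead of bromo, gives 78%, against 96% for compound 2; the two differ in two places, so the values only show that a ring with chloro beside the shared core still inhibits strongly. The bromo that compound 2 carries, whose removal cost heavily in the step to compound 3, is kept in compound 4. A modest loss is therefore expected, a number 11 percentage points lower from compound 2 to compound 4 (beyond the scatter), and compound 4 is estimated at 85%, within the range 65% to 98%.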

Compound 4, a percentage reported as inhibition, in the whole organism at one dose (the size of the read-out at that dose, not a potency): 86%
For compound 4 the middle estimate is 1 percentage points below the measured one; the measured number falls inside the stated range.
By their numbers in this assay, from the lowest: compound 3; then compounds 1, 4 and 2 (each within the scatter of the next, the first and the last beyond it).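

In this assay, chloro on the aromatic carbon ortho to a group of 8 heavy atoms and para to a bromo group gives a number 10 percentage points lower from compound 2 to compound 4 (within the scatter) and so leaves no change that can be told from the scatter. Among the compounds shown here, until now this chloro could be seen only in compound 1, which differs from compound 2 in two places, so this is the first reading of the chloro alone. The second new step gives a number 8 percentage points higher from compound 1 to compound 4 (within the scatter) and shows that, with the chloro present, bromo and fluoro on that ring cannot be told apart in this assay, unlike the large step seen earlier when methylsulfanyl stood in place of bromo on the ring without the chloro. Nothing given here bears on why these numbers fall as they do.

Open, going by these compounds, is whether an amine or a methoxy group on this same aromatic carbon would read like chloro, and whether chloro there would give the same result with methylsulfanyl in place of the bromo group. All of these readings also come from one dose, so they give the size of the inhibition at that dose and leave any difference in potency open.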